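The compounds below may be only part of what the source reports. "The series", "measured", "known", "first", "only" and "open" are said of these compounds alone.

Measured in a functional assay on MCF7 cells (Homo sapiens) for inhibition, with a stated time of 72 h; on this read-out lower numbers stand for stronger inhibition and higher numbers for weaker inhibition:
- compound 1 `NC1CCC(Nc2nc(NCc3ccc(Br)cc3)c3ncn(C4CCCC4)c3n2)CC1`: 850 nM
- compound 2 `OC1CCC(Nc2nc(NCc3ccc(-c4ccco4)nc3)c3ncn(C4CCCC4)c3n2)CC1`: 390 nM
- compound 3 `CC(C)(O)CNc1nc(NCc2ccc(-c3ccco3)nc2)c2ncn(C3CCCC3)c2n1`: 1310 nM

Compound 1 lies within the scatter of compound 3, while compound 2 stands lower than compound 1, beyond the scatter. Compound 4 `NC1CCC(Nc2nc(NCc3ccc(-c4ccccc4O)cc3)c3ncn(C4CCCC4)c3n2)CC1` departs from compound 1 as follows: 2-hydroxyphenyl in place of bromo on an aromatic carbon. Among the compounds with values here, the only measured step, a 3.4-fold higher number from compound 2 to compound 3 (0.53 log units; beyond the scatter), lies at another site and offers a size scale only. Within the data shown here, no measured step tests the bromo site itself. Compounds 2 and 3 also carry an aromatic ring where compound 1 has bromo, but the support is mixed: compound 2 gives 390 nM and compound 3 gives 1310 nM. A modest move to a lower number is therefore expected in this assay. The expected step is a 2.8-fold lower number from compound 1 to compound 4 (0.45 log units; beyond the scatter). For compound 4 the estimate is 300 nM, with an expected range of 80 nM to 900 nM.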

Compound 4, half-maximal inhibitory concentration: 2910 nM
Estimate against measurement, compound 4: 9.7-fold (0.99 log units) below; the whole stated range lies below it.
By their numbers in this assay, from the lowest: compound 2; then compounds 1 and 3 (each within the scatter of the next); then compound 4.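

In this assay, the bromo site now has its first direct test: 2-hydroxyphenyl in place of bromo gives a 3.4-fold higher number from compound 1 to compound 4 (0.53 log units; beyond the scatter), so this larger group on the aromatic carbon, para to a large group, moves the number up rather than down. The position is therefore not indifferent to this change. Nothing shown gives a reason for the rise.

Going by these compounds, compound 4 brings in a ring and a hydroxyl together, so their separate contributions remain open. An unsubstituted phenyl or a 2-methoxyphenyl at this carbon would help separate them.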